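Removing the bromo group from a diphenylaminomethyl analog

The compounds below may be only part of what the source reports. "The series", "measured", "known", "first", "only" and "open" are said of these compounds alone.

Measured compounds:
Compound 1, `Cc1ccc2nc(/N=C3\C(=O)N(CN4CCCCC4)c4ccccc43)sc2c1`: 38900 nM
Compound 2, `Cc1ccc2nc(/N=C3\C(=O)N(CN(c4ccccc4)c4ccccc4)c4cccc(Br)c43)sc2c1`: 67900 nM

Of the compounds shown here, two share a core and have been tested in an ADME assay on MCF-10A cells (Homo sapiens) for cytotoxicity, read by sulforhodamine B assay, with a stated time of 48 h; a higher number here means a weaker inhibitor of growth, a lower number a stronger inhibitor of growth. Compound 1 gives 38900 nM in this assay. Compound 2 gives 67900 nM in this assay. The gap between these two numbers is within the usual scatter, so neither can be called the stronger or weaker inhibitor of growth; both are weak inhibitors on this scale.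

Compound 3, `Cc1ccc2nc(/N=C3\C(=O)N(CN(c4ccccc4)c4ccccc4)c4ccccc43)sc2c1`, is not yet measured. It differs from compound 2 in one place: hydrogen in place of bromo on an aromatic carbon. Since compound 1, which also carries no bromo, gives a number within the scatter of compound 2, there is no sign in these data that the bromo group matters for growth inhibition. Within the data shown here, no step between measured compounds shows the effect of this change directly, so no step beyond the scatter is expected in this assay in either direction. For compound 3 the expected value in this assay is 50000 nM, with a range from 20000 nM to 120000 nM, which is the estimated step of a 1.4-fold lower number from compound 2 to compound 3 (0.13 log units; within the scatter).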

Compound 3, concentration for 50% growth inhibition: 34000 nM
For compound 3 the middle estimate is 1.5-fold (0.17 log units) above the measured one; the measured number falls inside the stated range.
By their numbers in this assay, from the lowest: compounds 3, 1 and 2 (each within the scatter of the next).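

Among these compounds, this is the first direct look at the bromo group on its aromatic carbon, as only this one place differs: in this assay the step is a 2.0-fold lower number from compound 2 to compound 3 (0.30 log units; within the scatter) when hydrogen stands in place of bromo. At this position, then, the bromo group can be exchanged for hydrogen with no difference that this measurement can separate from its normal scatter, and both compounds remain weak inhibitors of growth. Nothing in the data offers an explanation for this result.

As far as these compounds go, it remains open whether another group on this same aromatic carbon, such as an amine, a methoxy group or a nitrile, would produce a step beyond the scatter. From the compounds shown here alone, it is also open whether bromo at this place would give a similarly small step on compound 1, whose side chain differs from the diphenylaminomethyl group carried by the other two compounds.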